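The source may hold more compounds than are shown below. What is called first, only, known or untested is meant among the compounds shown, and "the series" means these compounds.

Compound 3, `O=C(O)[C@H](CO)NC(=O)[C@@H]1C[C@@H](O)CN1`, stands highest of the two numbers given in an ADME assay on Jejunum (Mus musculus, strain C57BL/6) for metabolic stability, read by HPLC, with a stated time of 12 h (on this read-out higher numbers stand for a longer-lived compound and lower numbers for a shorter-lived compound), where compound 3 gives 0.35 h; its nearest neighbour is compound 1, `O=C(N[C@H](CO)C(=O)O)[C@@H]1C[C@@H](O)CN1`, which gives 0.33 h, a gap within the scatter. Compound 2, `O=C(N[C@H](CO)C(=O)O)[C@@H]1C[C@H](O)CN1`, is reported only as a limit of this assay, > 12 h.

Compound 4, `O=C(O)[C@@H](CO)NC(=O)[C@H]1C[C@@H](O)CN1`, is to be measured next. the two compounds have the same atoms and bonds and differ only in configuration as drawn: 2 of 3 stereo elements differ; a stereocentre at a saturated chain carbon is drawn S in compound 3 and R in compound 4; a stereocentre at a saturated ring carbon is drawn S in compound 3 and R in compound 4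

Within the data shown here, two measured steps bear on this change. The step of a 1.1-fold higher number from compound 1 to compound 3 (0.03 log units; within the scatter) inverts a chain carbon alone and stays within the scatter. The step of an at least 36-fold higher number from compound 1 to compound 2 (1.56 log units; beyond the scatter) inverts a ring carbon alone and is large; likewise an at least 34-fold lower number from compound 2 to compound 3 (1.53 log units; beyond the scatter) inverts both a chain and a ring carbon and is large. The chain inversion is therefore expected to contribute little, while the ring inversion could move the half-life strongly in either direction; the larger swing is expected to come from the ring carbon. Compound 4 is estimated at 0.7 h, within 0.2 h to 6 h, which means an expected step of a 2.0-fold higher number from compound 3 to compound 4 (0.30 log units; within the scatter).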

Compound 4, half-life in the Mus musculus assay: > 12 h
Compound 4: only a limit was reported; the forecaster's own chance of this, stated with the estimate: 20%; middle value at least 17-fold (1.23 log units) away from the limit.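

In the Mus musculus assay there is an at least 36-fold higher number from compound 1 to compound 4 (1.56 log units; beyond the scatter), and this single inversion involves a different ring carbon from the one that separates compound 1 from compound 2, so a second ring stereocentre also carries a large step, which rests on configuration alone: the fact that compounds 1 and 4 differ only in the configuration as drawn

the Mus musculus assay also gives an at least 34-fold higher number from compound 3 to compound 4 (1.53 log units; beyond the scatter), where a chain carbon inverts together with that ring carbon.

In a physicochemical assay for metabolic stability, read by HPLC, in phosphate buffer, with a stated time of 12 h, at pH 6.8 (on this read-out higher numbers stand for a longer-lived compound and lower numbers for a shorter-lived compound), compound 3 gives > 12 h, which is a limit.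

Going by these compounds, in the physicochemical assay compound 4 gives > 12 h, also a limit, and the steps that join two limits cannot be read, so any difference between such compounds stays open.

Also open, on these data alone, is whether either ring inversion would have the same effect with an amine in place of the ring hydroxyl or an ester in place of the carboxylic acid.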